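Swapping a Halogenated Benzyl Group on Two Related Cores

The source may report more compounds than this note shows. Statements on the series, on what has been measured and on what is new or still open speak of the compounds shown alone.

Compound 1 `Cc1ccc(/C=C2\CN(C(=S)SCc3cn(Cc4cccc(Cl)c4)nn3)C/C(=C\c3ccc(C)cc3)C2=O)cc1` and compound 2 `Cc1ccc(/C=C2\CN(C(=S)SCc3cn(Cc4ccccc4F)nn3)C/C(=C\c3ccc(C)cc3)C2=O)cc1` share one core. In a functional assay on MDA-MB-231 cells (Homo sapiens) for cytotoxicity, read by MTT assay, with a stated time of 24 h (on this read-out higher numbers stand for weaker inhibition and lower numbers for stronger inhibition), compound 1 gives 83000 nM, and compound 2 gives 91500 nM. The change between them, (2-fluorophenyl in place of 3-chlorophenyl on a saturated chain carbon bound to an aromatic nitrogen), made a 1.1-fold higher number from compound 1 to compound 2 (0.04 log units; within the scatter). Compound 3 `Cc1ccc(/C=C2\CN(Cc3cn(Cc4cccc(Cl)c4)nn3)C/C(=C\c3ccc(C)cc3)C2=O)cc1` carries the same 3-chlorobenzyl group on a different core; the difference between the two cores is not broken down here. In this assay compound 3 gives 9000 nM, the lowest of the three values. Compound 4 `Cc1ccc(/C=C2\CN(Cc3cn(Cc4ccccc4F)nn3)C/C(=C\c3ccc(C)cc3)C2=O)cc1` differs from compound 3 by the same change, (2-fluorophenyl in place of 3-chlorophenyl on a saturated chain carbon bound to an aromatic nitrogen). A step of similar size is expected for compound 4, namely a 1.1-fold higher number from compound 3 to compound 4 (0.05 log units; within the scatter), because the same change between compound 1 and compound 2 gave only a 1.1-fold higher number from compound 1 to compound 2 (0.04 log units; within the scatter). Compound 4 is therefore estimated at 10000 nM, most likely between 4000 nM and 25000 nM.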

Compound 4, half-maximal inhibitory concentration: 10000 nM
For compound 4 middle estimate and measured number coincide at the digits printed; measured number inside the range.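

Putting 2-fluorophenyl in place of 3-chlorophenyl on the core of compound 3 makes no difference that can be read in this assay: the result is a 1.1-fold higher number from compound 3 to compound 4 (0.05 log units; within the scatter). Set beside the earlier step, the same change behaves alike on both cores: the same change on two cores in this assay, a 1.1-fold higher number (0.04 log units; within the scatter) from compound 1 to compound 2 and a 1.1-fold higher number (0.05 log units; within the scatter) from compound 3 to compound 4, 1.0-fold (0.00 log units) apart, within the scatter of two such steps. This shows that the swap leaves the number within the scatter on these two cores in this one assay, but it does not show that the two groups are interchangeable elsewhere, or that a change with a larger step would carry over as well.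

The compounds shown carry only these two halogenated benzyl groups. Open, from the compounds shown here alone, is what a plain benzyl, a longer chain such as phenethyl, or a benzyl bearing an amine or a carboxylic acid would do at the same place on either core.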